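Two Limits and a Larger Amine

The source may report more compounds than this note shows. Statements on the series, on what has been measured and on what is new or still open speak of the compounds shown alone.

Measured in a functional assay on the whole organism for positive allosteric modulation, with Mus musculus as the target; a lower number here means that less compound is needed, a higher number that more compound is needed for the effect:
Compound 1 `Cc1cc(-c2ccccc2)nnc1NCCCCN`: > 30 mg/kg, a limit
Compound 2 `Cc1cc(-c2ccccc2)nnc1NCCN(C)C`: > 30 mg/kg, a limit

Compound 2 stands at the limit of > 30 mg/kg in this assay, at which 2 of the 2 values shown sit, which makes its value a limit and not a number. Within the data shown here, the only measured step is a step that the two limits leave unreadable from compound 1 to compound 2, so it offers no size to carry forward.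

Compound 3 `CCN(CC)CCNc1nnc(-c2ccccc2)cc1C` keeps the shared core and changes one group: diethylamino in place of dimethylamino on a saturated chain carbon, two bonds along the chain from a nitrogen on an aromatic ring. It has diethylamino in place of dimethylamino on a saturated chain carbon, two bonds along the chain from a nitrogen on an aromatic ring.

With no readable step to guide it, the expectation stays loose, and another limit would be no surprise. The expected step in this assay is a number no higher from compound 2 to compound 3 (the limit leaves the size open), with no firm direction. For compound 3 the estimated dose is 30 mg/kg, with an expected range of 10 mg/kg to 60 mg/kg.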

Compound 3, dose for half-maximal effect: > 30 mg/kg
Compound 3: only a limit was reported; the forecaster's own chance of this, stated with the estimate: 60%; the middle value lies on the limit itself.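

Compound 3 also gives only a limit, so the steps linking it to compound 1 and compound 2 cannot be read: the limit of > 30 mg/kg in this assay, at which 3 of the 3 values shown sit.

The compounds shown leave open what dose of each gives the half-maximal effect in this assay, and whether changing the amine group shifts that dose.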